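This account rests on a few compounds, and the source may have more. Where it says the series, first, only, none or still open, it means among the compounds named here.

Compound 2 `CCCCCCCCCCCC[C@@H](O)[C@H]1CC[C@H]([C@H](O)CCCCCCCCCCNC(=O)c2cncs2)O1` is one of two measured compounds, and in a functional assay on MCF7 cells (Homo sapiens) for inhibition, read by colorimetric assay and sulforhodamine B assay, with a stated time of 48 h (on this read-out lower numbers stand for stronger inhibition of growth and higher numbers for weaker inhibition of growth), compound 2 gives 100000 nM. Its nearest measured relative is compound 1 `CCCCCCCCCCCC[C@@H](O)[C@H]1CC[C@H]([C@H](O)CCCCCCCCCCNC(=O)c2ccco2)O1`, which in this assay gives 100000 nM. The one step so far, no change at the digits printed from compound 1 to compound 2 (within the scatter), shows that swapping one five-membered aromatic ring for another on the carbonyl carbon of the amide left the result unchanged within the scatter, and compound 2 therefore stands level with compound 1 on the numbers shown.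

Compound 3 `CCCCCCCCCCCC[C@@H](O)[C@H]1CC[C@H]([C@H](O)CCCCCCCCCCNC(=O)c2ccnn2C)O1` is not yet measured. It differs from compound 2 in one place: 1-methyl-1H-pyrazol-5-yl in place of 1,3-thiazol-5-yl on a carbonyl carbon. This is again an exchange of one small aromatic ring for another at the same carbonyl carbon, the kind of change that gave no shift from compound 1 to compound 2. On that basis no step beyond the scatter is expected in this assay, and the step from compound 2 to compound 3 is estimated as no change at the digits printed from compound 2 to compound 3 (within the scatter). Compound 3 is therefore expected to give about 100000 nM in this assay, with a likely range from 50000 nM to 100000 nM.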

Compound 3, concentration for 50% growth inhibition: 3240 nM
Compound 3: middle estimate off by 31-fold (1.49 log units), on the high side, and the stated range ends above it.
By their numbers in this assay, from the lowest: compound 3; then compounds 1 and 2 (each within the scatter of the next).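

In this assay, the ring on the carbonyl carbon of the amide turns out to matter, since the change to 1-methyl-1H-pyrazol-5-yl gives a 31-fold lower number from compound 2 to compound 3 (1.49 log units; beyond the scatter) and also a 31-fold lower number from compound 1 to compound 3 (1.49 log units; beyond the scatter), whereas the earlier exchange gave only no change at the digits printed from compound 1 to compound 2 (within the scatter). So being a small aromatic ring is not enough to predict the result at this position: 1,3-thiazol-5-yl and 1-methyl-1H-pyrazol-5-yl are both five-membered aromatic rings with the same counts of hetero atoms, hydrogen-bond donors and hydrogen-bond acceptors, and neither carries a net charge, yet they stand far apart in this read-out. No measurement at hand bears on why this ring stands apart from the other two.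

The compounds shown cannot separate the part played by the methyl group from that of the ring itself, and a pyrazole without the methyl group or with an ethyl group in its place would address that question. They also leave open how a six-membered ring such as phenyl or pyridine, or an amine attached to the pyrazole, would behave on the same carbonyl carbon.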